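Swapping Furan-3-yl for Iodo at the Assay Limit

A few compounds are considered here, and "the series" means these few. Any claim that something is new, unique, unknown or untested is made for them only; others in the source may bear on it.

In a functional assay on HeLa S3 cells (Homo sapiens) for antiproliferative activity, read by XTT assay, with a stated time of 72 h (on this read-out higher numbers stand for weaker inhibition and lower numbers for stronger inhibition), compound 1 (`CNc1ncnc2c1c(-c1ccoc1)cn2[C@@H]1O[C@H](CO)[C@@H](O)[C@H]1O`) gives > 20000 nM, which is a limit and not a number. From the compounds shown here alone, compound 2 (`Cc1ncnc2c1c(-c1ccoc1)cn2[C@@H]1O[C@H](CO)[C@@H](O)[C@H]1O`) gives > 20000 nM, which is also a limit, so its true potency is unknown. The evidence so far amounts to the limit of > 20000 nM in this assay, at which 2 of the 2 values shown sit. Compound 3 (`Cc1ncnc2c1c(I)cn2[C@@H]1O[C@H](CO)[C@@H](O)[C@H]1O`) carries iodo in place of furan-3-yl on an aromatic carbon. Among the measured compounds shown here, the only measured step, a step that the two limits leave unreadable from compound 1 to compound 2, has no readable size and keeps furan-3-yl, so it offers nothing to carry over to this exchange. For the measured compounds named here, no measured step covers the loss of furan-3-yl. A readable value could only lie on the stronger side of the limit, although another limit remains quite possible. The expected change is an at least 3.3-fold lower number from compound 2 to compound 3 (0.52 log units; beyond the scatter), towards stronger inhibition, and this estimate is loose. For compound 3 the estimated value is 6000 nM, with an expected range from 500 nM to 20000 nM.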

Compound 3, half-maximal inhibitory concentration: 4080 nM
Compound 3: the middle estimate sits 1.5-fold (0.17 log units) above what was measured; the measured number falls inside the stated range.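

In this assay, among the compounds shown here, the exchange of furan-3-yl for iodo gives an at least 4.9-fold lower number from compound 2 to compound 3 (0.69 log units; beyond the scatter), the first change in this set with a readable size. Compound 2 sits at a limit, so this size is only a minimum and the true step may be larger. The result shows that this aromatic carbon responds to its substituent, with one heavy atom in place of five giving a measurable number, whereas the step from methylamino to methyl cannot be read: the limit of > 20000 nM in this assay, at which 2 of the 3 values shown sit.

The compounds shown cannot separate the loss of furan-3-yl from the arrival of iodo, as one exchange does both. Nor do they tell how a chloro group, an amine or a longer chain would behave at this position, or whether methylamino would change the number with iodo in place.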